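This account rests on a few compounds, and the source may have more. Where it says the series, first, only, none or still open, it means among the compounds named here.

Of the compounds shown here, two have been tested in a functional assay on the whole organism (strain albino) for inhibition, with Rattus norvegicus as the target, read by paw edema, with stated times of 30 min and 2 h, at a dose of 100 mg/kg by the oral route (on this read-out higher numbers stand for more inhibition at the one dose given (going by the name of the read-out) and lower numbers for less inhibition), so far. Compound 1 `O=C(CO[N+](=O)[O-])Nc1ccc(C(=O)/C=C/c2ccco2)cc1` gives 36% in this assay, and compound 2 `COc1ccc(/C=C/C(=O)c2ccc(NC(=O)COc3ccc(C(C)=O)cc3)cc2)cc1` gives 35% in this assay; compound 2's number stands alongside that of compound 1, the gap between them lying within the usual scatter. Compound 3 `CC(=O)c1ccc(OCC(=O)Nc2ccc(C(=O)/C=C/c3ccco3)cc2)cc1` shares the amide side of compound 2 and differs only in furan-2-yl in place of 4-methoxyphenyl on a double-bonded chain carbon bound to a double-bonded chain carbon. Since compound 1 carries the same furan-2-yl group and gives 36%, no step beyond the scatter is expected; the step from compound 2 to compound 3 is estimated as no change at the digits printed from compound 2 to compound 3 (within the scatter). Compound 3 is expected to give about 35% in this assay, with a likely range from 22% to 48%.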

Compound 3, a percentage reported as inhibition, in the whole organism at one dose (the size of the read-out at that dose, not a potency): 32%
For compound 3 the middle estimate is 3 percentage points above the measured one; the range from low to high includes it.
By their numbers in this assay, from the lowest: compounds 3, 2 and 1 (each within the scatter of the next).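

In this assay, furan-2-yl in place of 4-methoxyphenyl on a double-bonded chain carbon bound to a double-bonded chain carbon gives a number 3 percentage points lower from compound 2 to compound 3 (within the scatter), so either ring can stand at this position without a step that can be told from the scatter. At the other end of the molecule, 4-acetylphenyl in place of nitro on an oxygen on a saturated carbon gives a number 4 percentage points lower from compound 1 to compound 3 (within the scatter) and likewise shows no readable step. Nothing measured here offers an explanation of either step.

Still open, from the compounds shown here alone, is whether a phenyl ring carrying an amine or a carboxylic acid, or a saturated alkyl chain in place of the ring, would hold the number at this position. The compounds shown also leave open whether any change at either end can move the number beyond the scatter.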